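The source may hold more compounds than are shown below. What is called first, only, known or untested is meant among the compounds shown, and "the series" means these compounds.

Measured so far in a functional assay on MCF7 cells (Homo sapiens) for inhibition, with a stated time of 96 h; on this read-out lower numbers stand for stronger inhibition and higher numbers for weaker inhibition
- compound 1 `COc1cc(C(=O)c2cn(-c3ccc(C)cc3)cc2-c2ccco2)cc(OC)c1OC` at 22 nM
- compound 2 `COc1cc(C(=O)c2cn(-c3ccc(C)cc3)cc2-c2ccoc2)cc(OC)c1OC` at 18 nM
- compound 3 `COc1cc(C(=O)c2cn(-c3ccc(C)cc3)cc2-c2ncco2)cc(OC)c1OC` at 42 nM

Compound 3 stands at 42 nM in this assay on these numbers. The measured step of a 2.3-fold higher number from compound 2 to compound 3 (0.37 log units; beyond the scatter) is modest and beyond the scatter, while a 1.9-fold higher number from compound 1 to compound 3 (0.28 log units; within the scatter) stays within it.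

Compound 4 `COc1cc(C(=O)c2cn(-c3ccc(C)cc3)cc2-c2ccccn2)cc(OC)c1OC` carries pyridin-2-yl in place of 1,3-oxazol-2-yl on an aromatic carbon.

The measured steps at this place are all exchanges among five-membered aromatic rings. Besides the two above, a 1.2-fold lower number from compound 1 to compound 2 (0.09 log units; within the scatter) lies within the scatter, so none of the three is larger than modest. Among the compounds with values here, no measured compound has a six-membered aromatic ring here, so that part of the change is untested and the range is kept wide.

The expected result is a 1.1-fold lower number from compound 3 to compound 4 (0.02 log units; within the scatter) in this assay and amounts to no step beyond the scatter. For compound 4 the estimated value is 40 nM with an expected range from 12 nM to 130 nM in this series.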

Compound 4, half-maximal inhibitory concentration: 36 nM
For compound 4 the middle estimate is 1.1-fold (0.05 log units) above the measured one; low and high end bracket the measured number.
By their numbers in this assay, from the lowest: compounds 2, 1, 4 and 3 (each within the scatter of the next, the first and the last beyond it).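

In this assay, a six-membered aromatic ring is now represented at this position, and the exchange of 1,3-oxazol-2-yl for pyridin-2-yl gives a 1.2-fold lower number from compound 3 to compound 4 (0.07 log units; within the scatter) so the larger ring separates these two compounds by no readable margin. The comparisons with the two furans read the same way: a 2.0-fold higher number from compound 2 to compound 4 (0.30 log units; within the scatter) and a 1.6-fold higher number from compound 1 to compound 4 (0.21 log units; within the scatter) show that pyridin-2-yl also stays level with furan-3-yl and furan-2-yl on these numbers. Nothing available explains why these rings read alike.

All four groups at this place are aromatic rings, so the shown compounds leave open how a plain phenyl, a saturated ring such as morpholine, an amine, a carboxylic acid or a longer alkyl chain would read here. As far as these compounds go, the pyridin-3-yl and pyridin-4-yl isomers also remain open.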